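The source may hold more compounds than are shown below. What is called first, only, known or untested is meant among the compounds shown, and "the series" means these compounds.

Compound 1 `COc1ccc(-c2c(C(=O)c3cc(OC)c(OC)c(OC)c3)sc3ccccc23)cc1`: 1600 nM
Compound 2 `COc1cc(C(=O)c2sc3ccccc3c2-c2ccc(SC)cc2)cc(OC)c1OC`: 1300 nM

In a functional assay on HL-60 cells (Homo sapiens) for antiproliferative activity, read by MTT assay, with a stated time of 72 h (a lower number here means a stronger inhibitor, a higher number a weaker inhibitor), compound 2 gives 1300 nM, which lies within the usual scatter of compound 1, so the two cannot be ranked. Compound 3 `COc1ccccc1-c1c(C(=O)c2cc(OC)c(OC)c(OC)c2)sc2ccccc12` carries 2-methoxyphenyl in place of 4-(methylsulfanyl)phenyl on an aromatic carbon of the five-membered aromatic ring: 2-methoxyphenyl in place of 4-(methylsulfanyl)phenyl on an aromatic carbon. Within the data shown here, only one measured step bears on this change: a 1.2-fold lower number from compound 1 to compound 2 (0.09 log units; within the scatter). It put methylsulfanyl in place of methoxy and stayed within the scatter. Among the measured compounds shown here, no measured compound carries the 2-methoxyphenyl group, however, so the data give no direct size for this change. The expected step in this assay is small and leans only loosely toward a higher number: a 1.5-fold higher number from compound 2 to compound 3 (0.19 log units; within the scatter). For compound 3 the estimated value is 2000 nM, with the result expected to fall from 500 nM to 8000 nM.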

Compound 3, half-maximal inhibitory concentration: 2900 nM
For compound 3 the middle estimate is 1.5-fold (0.16 log units) below the measured one; low and high end bracket the measured number.
By their numbers in this assay, from the lowest: compounds 2, 1 and 3 (each within the scatter of the next, the first and the last beyond it).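

In this assay, among these compounds, this is the first change on the aromatic carbon of the five-membered ring to go beyond the scatter, with a 2.2-fold higher number from compound 2 to compound 3 (0.35 log units; beyond the scatter) when 2-methoxyphenyl replaces 4-(methylsulfanyl)phenyl, though the step is only modest. Against the closer comparison, 2-methoxyphenyl in place of 4-methoxyphenyl gives a 1.8-fold higher number from compound 1 to compound 3 (0.26 log units; within the scatter) and stays within the scatter, so shifting the methoxy group around the phenyl ring has no effect that these numbers can separate from noise. Nothing measured here explains the gap between compound 2 and compound 3.

From the compounds shown here alone, whether an amine or a carboxylic acid on this phenyl ring would shift the number further in either direction remains open. So does whether methylsulfanyl in the 2-position of the phenyl ring would behave like 2-methoxyphenyl.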